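Amide cap variation in the chalcone series: working notes

A few compounds are considered here, and "the series" means these few. Any claim that something is new, unique, unknown or untested is made for them only; others in the source may bear on it.

Measured so far in a functional assay on HUVEC cells (Homo sapiens) for inhibition; a lower number here means a stronger inhibitor, a higher number a weaker inhibitor:
compound 1 `COc1cc(/C=C/C(=O)c2cccc(NC(=O)c3ccc(Cl)c(Cl)c3)c2)ccc1O` — 2.97 ug/mL
compound 2 `COc1cc(/C=C/C(=O)c2cccc(NC(=O)c3cc(Cl)cc(Cl)c3)c2)ccc1O` — 0.75 ug/mL

Compound 2 holds the lower of the two numbers; compound 1 sits at 2.97 ug/mL, a step of a 4.0-fold lower number from compound 1 to compound 2 (0.60 log units; beyond the scatter) away, a modest shift that nonetheless lies beyond the scatter. That step alters only the pattern of chlorines on the aromatic ring of the amide cap.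

Compound 3 `CCCC(=O)Nc1cccc(C(=O)/C=C/c2ccc(O)c(OC)c2)c1` makes a change of another kind: propyl in place of 3,5-dichlorophenyl on a carbonyl carbon. Going by the values given here, no measured step covers the exchange of an aromatic group for a chain on this carbonyl carbon. The step from compound 1 to compound 2 bears only indirectly, in showing that the group on the carbonyl carbon moves the number; it gives no direction for a propyl. The expectation is therefore anchored on compound 2 with a wide range, and a shift beyond the scatter in either direction would not surprise. For compound 3 the estimated value in this assay is 3 ug/mL, expected between 0.7 ug/mL and 15 ug/mL, corresponding to an expected step of a 4.0-fold higher number from compound 2 to compound 3 (0.60 log units; beyond the scatter).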

Compound 3, half-maximal inhibitory concentration: 1.27 ug/mL
Compound 3: middle estimate off by 2.4-fold (0.37 log units), on the high side, within the range that was stated.
By their numbers in this assay, from the lowest: compounds 2 and 3 (each within the scatter of the next); then compound 1.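

In this assay, the ring and both chlorines of the amide cap are not needed to keep the number of compound 2 at this carbonyl carbon: propyl gives a 1.7-fold higher number from compound 2 to compound 3 (0.23 log units; within the scatter). Against the other dichlorophenyl cap, the same chain gives a 2.3-fold lower number from compound 1 to compound 3 (0.37 log units; beyond the scatter), so among these three compounds only the 3,4-dichlorophenyl cap stands apart, and an aromatic cap is no condition for the lower numbers. Nothing in hand accounts for these differences.

Open, as far as these compounds go, is whether a longer chain, such as hexyl, or a branched one, such as isopropyl, stays at this level, or whether propyl is a particular case. The compounds shown also leave open how an unsubstituted phenyl cap, or a chain ending in an amine or a carboxylic acid, would read here.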